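The source may hold more compounds than are shown below. What is called first, only, known or untested is meant among the compounds shown, and "the series" means these compounds.

Measured so far:
- compound 1, `CC1(C)Oc2ccc(C#N)cc2[C@@H](NC(=O)Nc2ccccc2)[C@@H]1O`, gives 800 nM in a functional assay (aorta) with Rattus norvegicus as the target; a higher number here means a weaker inhibitor, a lower number a stronger inhibitor.
- compound 2, `CC1(C)Oc2ccc(C#N)cc2[C@@H](/N=C(\NC#N)Oc2ccccc2)[C@@H]1O`, gives > 100000 nM in this assay, which is a limit of the assay and not a number.

On these data alone, compound 2 therefore stands at the edge of what this assay can report: the limit of > 100000 nM in this assay, at which 1 of the 2 values shown sits, so its true potency is unknown beyond being weak. Compound 3, `CC1(C)Oc2ccc(C#N)cc2[C@@H](/N=C(\NC#N)Nc2ccc(C(=O)O)cc2)[C@@H]1O`, differs from compound 2 in a single place: (4-carboxyphenyl)amino in place of phenoxy on a carbon with a double bond to nitrogen. Within the data shown here, no pair of measured compounds shows the same change, so its effect is not yet known from data. The two measured values do show that compound 1 sits at a clear number while compound 2 sits at the limit, and compound 3 returns a nitrogen link like that of compound 1. I expect the step of an at least 20-fold lower number from compound 2 to compound 3 (1.30 log units; beyond the scatter) to go toward stronger inhibition, well beyond the scatter, though with wide uncertainty. For compound 3 the estimated value in this assay is 5000 nM, ranging from 500 nM to 100000 nM.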

Compound 3, half-maximal inhibitory concentration: > 100000 nM
Compound 3: only a limit was reported; the forecaster's own chance of this, stated with the estimate: 30%; middle value at least 20-fold (1.30 log units) from the limit.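

No step can be read from compound 2 to compound 3, because both are reported in this assay only as a limit and not as a number: the limit of > 100000 nM in this assay, at which 2 of the 3 values shown sit.

The compounds shown leave open whether (4-carboxyphenyl)amino in place of phenoxy changes potency at all.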